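Sulfonyl aryl variation at the shared core: compound 4

The compounds below may be only part of what the source reports. "The series", "measured", "known", "first", "only" and "open" are said of these compounds alone.

Three analogues sharing one core, differing only in the aryl group on the sulfonyl sulfur, have been measured. Compound 1 `Cc1ccc(S(=O)(=O)c2cnc3cc(Cl)ccc3c2N2CCC(C)CC2)cc1F` gives 85% in an assay on isolated protein for displacement of a labelled ligand from metabotropic glutamate receptor 5 (Homo sapiens), with a stated time of 60 min, tested at 1 uM; on this read-out higher numbers stand for more inhibition at the one concentration tested (going by the name of the read-out) and lower numbers for less inhibition. Compound 2 `COc1ccc(S(=O)(=O)c2cnc3cc(Cl)ccc3c2N2CCC(C)CC2)cc1Cl` gives 93% in this assay, and compound 3 `CC1CCN(c2c(S(=O)(=O)c3cc(F)cc(F)c3)cnc3cc(Cl)ccc23)CC1` gives 94% in this assay. Compound 3 holds the largest of the three numbers, but every step among them stays inside the usual scatter: a number 8 percentage points higher from compound 1 to compound 2 (within the scatter), a number 9 percentage points higher from compound 1 to compound 3 (within the scatter), a number 1 percentage points higher from compound 2 to compound 3 (within the scatter). Taken together the series shows that swapping one substituted phenyl for another on the sulfonyl sulfur has so far left the read-out at a similar level.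

Compound 4 `CC1CCN(c2c(S(=O)(=O)c3cccc(C#N)c3)cnc3cc(Cl)ccc23)CC1` continues this pattern of aryl exchange. 3-cyanophenyl in place of 3,5-difluorophenyl on a sulfonyl sulfur

For the measured compounds named here, the steps that bear on this change are the three aryl swaps already measured, all within the scatter, and they give no basis for expecting a shift beyond it. The step from compound 3 to compound 4 is therefore expected to be small, with no preferred direction: a number 4 percentage points lower from compound 3 to compound 4 (within the scatter). For compound 4 the estimate in this assay is 90%, within a range of 76% to 98%.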

Compound 4, a percentage reported as inhibition, at one concentration (the size of the read-out at that concentration, not a potency): 94%
The estimate for compound 4 lay 4 percentage points below the measured number, within the range that was stated.
By their numbers in this assay, from the lowest: compounds 1, 2, 3 and 4 (each within the scatter of the next).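

In this assay, the exchange that brings in 3-cyanophenyl on a sulfonyl sulfur gives no change at the digits printed from compound 3 to compound 4 (within the scatter), and the two comparisons with the other aryl groups give a number 1 percentage points higher from compound 2 to compound 4 (within the scatter) and a number 9 percentage points higher from compound 1 to compound 4 (within the scatter). The earlier compounds shown here carried only halogen, methyl and methoxy substituents on the phenyl ring, whereas compound 4 adds a nitrile, with its triple bond and one hydrogen-bond acceptor, and the read-out remains at a similar level across the four compounds. No measurement is available that explains why the nitrile and the two fluorines give such similar numbers.

As far as these compounds go, it remains open whether a carboxylic acid or an aminomethyl group on the phenyl ring, or a cyclohexyl group in place of the phenyl ring, would take the number beyond the scatter of this series. All four compounds also share the rest of the core and were read at one concentration, so the role of that remainder and any differences in potency among them stay undefined.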